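Swapping Formyl for a Hydroxypyrrolidine Acid Side Chain

The source may report more compounds than this note shows. Statements on the series, on what has been measured and on what is new or still open speak of the compounds shown alone.

In a functional assay on HeLa cells (Homo sapiens) for antiproliferative activity, read by CCK-8 assay, with a stated time of 48 h (a higher number here means a weaker inhibitor, a lower number a stronger inhibitor), compound 1 `COc1ccc(/C=C\c2cc(OC)c(OC)c(OC)c2)cc1OCc1ccc(CNC(C)(C)C(=O)O)cc1` gives > 10000 nM, which is a limit of the assay and not a number. Among the measured compounds shown here, compound 2 `COc1ccc(/C=C\c2cc(OC)c(OC)c(OC)c2)cc1OCc1ccc(C=O)cc1` gives 4800 nM, the only actual number so far. Compound 3 `COc1ccc(/C=C\c2cc(OC)c(OC)c(OC)c2)cc1OCc1ccc(CN2C[C@H](O)C[C@@H]2C(=O)O)cc1` carries (2-carboxy-4-hydroxypyrrolidin-1-yl)methyl in place of formyl on an aromatic carbon. For the measured compounds named here, the one measured step bearing on this is an at least 2.0-fold lower number from compound 1 to compound 2 (0.31 log units; beyond the scatter), bounded by the limit of > 10000 nM in this assay, at which 1 of the 2 values shown sits. That step put formyl in place of ((1-carboxy-1-methylethyl)amino)methyl, and the change to compound 3 runs the opposite way with a different group. A higher number is therefore expected, as an estimated 1.9-fold higher number from compound 2 to compound 3 (0.27 log units; within the scatter). The estimate for compound 3 is 9000 nM, with an expected range of 3000 nM to 25000 nM.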

Compound 3, half-maximal inhibitory concentration: > 10000 nM
Compound 3: a limit, no number (the forecaster's own chance of this, stated with the estimate: 55%); middle value at least 1.1-fold (0.04 log units) from the limit.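

At this aromatic carbon, in this assay, (2-carboxy-4-hydroxypyrrolidin-1-yl)methyl in place of formyl gives an at least 2.0-fold higher number from compound 2 to compound 3 (0.31 log units; beyond the scatter). Of the three groups compared here, only formyl gives an actual number, and both side chains carrying a carboxylic acid end at a limit. The step between the two limit compounds cannot be read, and their side chains stay unranked: the limit of > 10000 nM in this assay, at which 2 of the 3 values shown sit.

On these data alone, it remains open whether the carboxylic acid or the amine nitrogen goes with the higher number. A methyl ester of the same side chain or a simple aminomethyl group would separate the two.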